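A few compounds are considered here, and "the series" means these few. Any claim that something is new, unique, unknown or untested is made for them only; others in the source may bear on it.

Measured so far:
compound 1, `O=C(CSc1nc2ccccc2[nH]1)c1ccc(O)cc1`: "not active" (no number reported)
compound 2, `CCOc1ccc(C(=O)CSc2nc3ccccc3[nH]2)cc1`: 55.2%
compound 3, `COc1ccc(C(=O)CSc2nc3ccccc3[nH]2)cc1O`: 49.7%

These three compounds share one core and differ only in the groups on the outer six-membered ring. In a functional assay on HT-29 cells (Homo sapiens) for inhibition, read by flow cytometry, tested at 10 uM (on this read-out higher numbers stand for more inhibition at the one concentration tested (going by the name of the read-out) and lower numbers for less inhibition), compound 1 gives "not active" (no number reported), with no number reported. Compound 2 gives 55.2% and compound 3 gives 49.7%; the two numbers lie within the usual scatter of each other, so neither can be called stronger or weaker than the other.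

Compound 4, `COc1ccc(C(=O)CSc2nc3ccccc3[nH]2)cc1`, has not been measured. It differs from compound 3 in one place:

hydrogen in place of hydroxy on an aromatic carbon

For the measured compounds named here, no pair of measured compounds shows this change, so no measured step guides the prediction. The step of a number 0.3 percentage points higher from compound 3 to compound 4 (within the scatter) is expected to stay within the scatter, in no firm direction. For compound 4 the estimate in this assay is 50%, with a range from 25% to 70%.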

Compound 4, a percentage reported as inhibition, at one concentration (the size of the read-out at that concentration, not a potency): 52.6%
Beside the measured number, compound 4's estimate is 2.6 percentage points below it; low and high end bracket the measured number.
By their numbers in this assay, from the lowest: compounds 3, 4 and 2 (each within the scatter of the next).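

In this assay, the hydroxy ortho to the methoxy group can be replaced by hydrogen without a change that stands out from the scatter (a number 2.9 percentage points higher from compound 3 to compound 4 (within the scatter)). Trimming the ethoxy group to methoxy also stays within the scatter (a number 2.6 percentage points lower from compound 2 to compound 4 (within the scatter)). Nothing available explains why either change leaves the read-out so steady.

From the compounds shown here alone, whether an amine or a carboxylic acid on this aromatic carbon would behave like hydroxy and hydrogen remains open. So does the effect of a chain longer than ethoxy on the oxygen.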